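Two chain stereocentres inverted: compound 2 to compound 4

A few compounds are considered here, and "the series" means these few. Any claim that something is new, unique, unknown or untested is made for them only; others in the source may bear on it.

In a functional assay on the whole organism with Mus musculus as the target (on this read-out higher numbers stand for an effect only at larger amounts of compound and lower numbers for an effect already at smaller amounts), compound 2 `CCCC[C@@](C)(OC)[C@H](O)/C=C/C1[C@H](O)C[C@H](O)[C@@H]1C/C=C\CCCC(=O)OC` gives 0.888 mg/kg. This lies within the scatter of compound 3 `CCCC[C@@](C)(OC)[C@H](O)/C=C/C1[C@H](O)CC(=O)[C@@H]1C/C=C\CCCC(=O)OC` at 0.757 mg/kg, while compound 1 `CCCC[C@](C)(OC)[C@H](O)/C=C/C1[C@H](O)C[C@H](O)[C@@H]1C/C=C\CCCC(=O)OC` stands higher at 1.82 mg/kg.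

The open case is compound 4 `CCCC[C@](C)(OC)[C@@H](O)/C=C/C1[C@H](O)C[C@H](O)[C@@H]1C/C=C\CCCC(=O)OC`, reached by the change (the two compounds have the same atoms and bonds; at least one stereo element is drawn with a configuration in one of them and without one in the other: 2 of 8 stereo elements differ; a stereocentre at a saturated chain carbon is drawn R in compound 2 and S in compound 4; a stereocentre at a saturated chain carbon is drawn R in compound 2 and S in compound 4). For the measured compounds named here, only one measured step concerns a stereocentre at a saturated chain carbon: a 2.0-fold lower number from compound 1 to compound 2 (0.31 log units; beyond the scatter). That step is modest but beyond the scatter, and its centre is drawn S in compound 1 and R in compound 2. The change to compound 4 also runs between R and S at such a carbon, and going from R to S was the direction of the higher number in that pair. Going by the values given here, no measured step covers a second inverted centre, so its contribution remains open and the range has to stay wide.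

In this assay, the expected move is upward, with an estimated 3.4-fold higher number from compound 2 to compound 4 (0.53 log units; beyond the scatter). For compound 4 the estimated value is 3 mg/kg, with an expected range of 1 mg/kg to 10 mg/kg.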

Compound 4, dose for half-maximal effect: > 4 mg/kg
Compound 4: no number, only a limit; the forecaster's own chance of this, stated with the estimate: 15%; middle value at least 1.3-fold (0.12 log units) away from the limit.
By their numbers in this assay, from the lowest: compounds 3 and 2 (each within the scatter of the next); then compound 1. At a limit, above all of these: compound 4.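

Compound 4 gives > 4 mg/kg in this assay, and this is a limit of the assay, not a number. The earlier pair moved only one saturated chain stereocentre; inverting the other one alone, drawn R and then S, gives an at least 2.1-fold higher number from compound 1 to compound 4 (0.34 log units; beyond the scatter), so this second centre also bears on the read-out. With both centres inverted, the step reads an at least 4.5-fold higher number from compound 2 to compound 4 (0.65 log units; beyond the scatter).

On these data alone, how far compound 4 lies past its limit stays open, so the two centres cannot yet be weighed against each other. Also open, as far as these compounds go, is whether the same inversions carry over to the carbonyl of compound 3, or to a carboxylic acid in place of the methyl ester.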